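The compounds below may be only part of what the source reports. "The series", "measured", "known", "first", "only" and "open" are said of these compounds alone.

Measured in an ADME assay on microsomes from liver (Mus musculus) for metabolic stability, read by LC-MS, with a stated time of 1 h, tested at 5 uM; a higher number here means that more of the compound is left, a lower number that less of the compound is left:

Compound 1 `Cc1nc(-c2ccccc2)c(C(=O)N2CCN(c3cccc(C)c3C)CC2)o1`: 83.6%
Compound 2 `COc1cc(OC)cc(N2CCN(C(=O)c3oc(C)nc3-c3ccccc3F)CC2)c1`: 16.6%
Compound 3 `COc1cc(OC)cc(N2CCN(C(=O)c3oc(C)nc3-c3cccc(F)c3)CC2)c1`: 11.6%

Compound 1 stands highest of the three, beyond the scatter from both others. Compound 4 `COc1cc(OC)cc(N2CCN(C(=O)c3oc(C)nc3-c3ccccc3)CC2)c1` has not yet been measured. It differs from compound 1 by 3,5-dimethoxyphenyl in place of 2,3-dimethylphenyl on an amine nitrogen in a ring, with 3,5-dimethoxyphenyl in place of 2,3-dimethylphenyl on an amine nitrogen in a ring.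

Among the measured compounds shown here, the one measured step, a number 5 percentage points lower from compound 2 to compound 3 (within the scatter), leaves this group untouched and offers only indirect guidance. Both of its compounds carry 3,5-dimethoxyphenyl, with compound 2 at 16.6% and compound 3 at 11.6%. A large fall beyond the scatter is therefore expected, a number 68.6 percentage points lower from compound 1 to compound 4 (beyond the scatter). Compound 4 is estimated at 15%, with an expected range from 6% to 30%.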

Compound 4, percent of the compound remaining: 0.7%
Estimate against measurement, compound 4: 14.3 percentage points above; the measured number lies below the stated range.
By their numbers in this assay, from the lowest: compound 4; then compounds 3 and 2 (each within the scatter of the next); then compound 1.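

Among the compounds shown here, the new compound shows that this position on the ring nitrogen carries most of the change in this assay: with the phenyl compound as the clean comparison, 3,5-dimethoxyphenyl in place of 2,3-dimethylphenyl gives the largest step so far (a number 82.9 percentage points lower from compound 1 to compound 4 (beyond the scatter)). It also shows that fluoro on the phenyl counts, since hydrogen in its place gives two modest falls (a number 10.9 percentage points lower from compound 3 to compound 4 (beyond the scatter); a number 15.9 percentage points lower from compound 2 to compound 4 (beyond the scatter)). Nothing measured here explains either change. Still open, from the compounds shown here alone, is whether the large fall follows the methoxy groups or the loss of the methyl groups, and how chloro or a nitrile would read at this position.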